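A few compounds are considered here, and "the series" means these few. Any claim that something is new, unique, unknown or untested is made for them only; others in the source may bear on it.

Compounds measured in an assay on isolated protein for inhibition of ubiquitin carboxyl-terminal hydrolase 7 (Homo sapiens), with stated times of 30 min and 2 h; a higher number here means a weaker inhibitor, a lower number a stronger inhibitor:
compound 1, `Cn1nc2c(=O)n(CC3(O)CCN(Cc4ccc(-c5ccco5)cc4Cl)CC3)cnc2c1-c1ccc(C(F)(F)F)cc1`, 530 nM
compound 2, `Cn1nc2c(=O)n(CC3(O)CCN(Cc4ccc(-c5ccco5)cc4Cl)CC3)cnc2c1-c1ccc(CNCCO)cc1`, 8.2 nM
compound 3, `Cn1nc2c(=O)n(CC3(O)CCN(Cc4ccc(-c5cccs5)cc4Cl)CC3)cnc2c1-c1ccc(CN)cc1`, 38.6 nM

Among the three numbers, compound 3 stands second highest in this assay: compound 2 gives the lowest number, compound 1 the highest, and compound 3 lies closer to compound 2 than to compound 1. Among the measured compounds shown here, the only step between measured compounds that differ in one place is a 65-fold lower number from compound 1 to compound 2 (1.81 log units; beyond the scatter), where a ((2-hydroxyethyl)amino)methyl group replaces a trifluoromethyl group on an aromatic carbon; that step is large, but it concerns a different position from the one changed here.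

Compound 4, `Cn1nc2c(=O)n(CC3(O)CCN(Cc4ccc(-c5ncco5)cc4Cl)CC3)cnc2c1-c1ccc(CN)cc1`, is compound 3 with 1,3-oxazol-2-yl in place of thiophen-2-yl on an aromatic carbon. Both groups are five-membered aromatic rings of the same heavy-atom count, the entering one carrying one more hetero atom and one more hydrogen-bond acceptor. For the measured compounds named here, no measured pair in this set changes this ring alone, so nothing here speaks for a step of any size in this assay. Compound 4 is therefore expected to give a number close to that of compound 3, with an estimated step of a 1.3-fold higher number from compound 3 to compound 4 (0.11 log units; within the scatter) that need not pass beyond the scatter. The estimate for compound 4 in this assay is 50 nM, within a range of 15 nM to 160 nM.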

Compound 4, half-maximal inhibitory concentration: 1120 nM
Beside the measured number, compound 4's estimate is 22-fold (1.35 log units) below it, outside the stated range (above it).
By their numbers in this assay, from the lowest: compound 2; then compound 3; then compound 1; then compound 4.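

In this assay, the ring on the aromatic carbon para to a large group and meta to a chloro group proves able to move the number strongly on its own: the exchange gives a 29-fold higher number from compound 3 to compound 4 (1.46 log units; beyond the scatter) as a large step, even though both rings are five-membered and aromatic with the same heavy-atom count. Among the compounds shown here, the earlier compounds offered no measured pair at this place, and their only step concerned a different position, so this pair is the first to show that the two rings are not interchangeable here, with the entering ring carrying one more hetero atom and one more hydrogen-bond acceptor. Nothing available explains the size of this step or assigns it to any one feature of the exchange.

The pair does not separate the roles of the ring nitrogen and the ring oxygen, and 1,3-thiazol-2-yl at this place would be needed to show whether a ring holding both sulfur and nitrogen stays nearer compound 3 or compound 4. Also open, from the compounds shown here alone, is how a plain phenyl ring or a pyridin-2-yl ring would compare at this place with the core of compound 3 otherwise unchanged.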